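Hydroxyphenyl Variants of a Purine Core in MCF7 Cytotoxicity

The compounds below may be only part of what the source reports. "The series", "measured", "known", "first", "only" and "open" are said of these compounds alone.

Compound 1, `Oc1ccccc1CNc1ncnc2c1ncn2C1CCCCO1`: > 100000 nM in an ADME assay on MCF7 cells (Homo sapiens) for cytotoxicity, with a stated time of 72 h (a lower number here means a stronger inhibitor, a higher number a weaker inhibitor), a limit of the assay.
Compound 2, `Oc1ccc(CNc2ncnc3c2ncn3C2CCCCO2)cc1`: > 100000 nM in this assay, again a limit.
Among the measured compounds shown here, compound 3, `COc1cccc(CNc2ncnc3c2ncn3C2CCCCO2)c1`: 97000 nM in this assay, the only number.

For the measured compounds named here, compound 3 thus stands as the sole read number, the other two sitting at the limit of > 100000 nM in this assay, at which 2 of the 3 values shown sit. The steps of an at least 1.0-fold lower number from compound 1 to compound 3 (0.01 log units; that floor lies within the scatter) and an at least 1.0-fold lower number from compound 2 to compound 3 (0.01 log units; that floor lies within the scatter) are floors within the scatter, and a step that the two limits leave unreadable from compound 1 to compound 2 cannot be read at all. Compound 4, `Oc1cc(O)cc(CNc2ncnc3c2ncn3C2CCCCO2)c1`, carries 3,5-dihydroxyphenyl in place of 3-methoxyphenyl on a saturated chain carbon bound to a nitrogen on an aromatic ring. Since compounds 1 and 2, each bearing a hydroxyphenyl, sit at a limit, compound 4 is expected to show no step beyond the scatter, a 1.0-fold higher number from compound 3 to compound 4 (0.01 log units; within the scatter), and is likely to return a limit. Compound 4 is estimated at 100000 nM, ranging from 40000 nM to 300000 nM.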

Compound 4, half-maximal inhibitory concentration: > 100000 nM
Compound 4: a limit, no number; the forecaster's own chance of this, stated with the estimate: 60%; the middle value lies on the limit itself.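

Replacing 3-methoxyphenyl with 3,5-dihydroxyphenyl at this position gives an at least 1.0-fold higher number from compound 3 to compound 4 (0.01 log units; that floor lies within the scatter), so even a ring carrying two hydroxy groups shows no readable change in this assay. Compound 1, compound 2 and compound 4 now share a single limit, with hydroxy groups at three different ring arrangements: the limit of > 100000 nM in this assay, at which 3 of the 4 values shown sit.

The steps among these three compounds cannot be read, and how far each lies past the limit stays open. Also open, on these data alone, is whether an amine, a carboxylic acid or a longer chain at this position would give a step beyond the scatter.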